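Swapping Methoxy for Amino on a Nucleoside Core

The source may hold more compounds than are shown below. What is called first, only, known or untested is meant among the compounds shown, and "the series" means these compounds.

Compound 2 `COc1ncnc2c1c(-c1cccs1)cn2[C@@H]1O[C@H](CO)[C@@H](O)[C@H]1O` gives 4850 nM in a functional assay on A549 cells (Homo sapiens), read by MTT assay, with a stated time of 72 h; on this read-out lower numbers stand for stronger inhibition and higher numbers for weaker inhibition. For compound 3 `COc1nc(N)nc2c1c(-c1cccs1)cn2[C@@H]1O[C@H](CO)[C@@H](O)[C@H]1O` this assay reports only a limit, > 20000 nM. For compound 1 `Cc1nc(N)c2c(-c3cccs3)cn([C@@H]3O[C@H](CO)[C@@H](O)[C@H]3O)c2n1` the report is also a limit, > 20000 nM. Compound 3 therefore stands at the weak end of what has been measured, as the limit of > 20000 nM in this assay, at which 2 of the 3 values shown sit, shows. Going by the values given here, the one measured step, an at least 4.1-fold higher number from compound 2 to compound 3 (0.61 log units; beyond the scatter), already shows an added amino group pushing the value past that limit. Compound 4 `Nc1nc(N)c2c(-c3cccs3)cn([C@@H]3O[C@H](CO)[C@@H](O)[C@H]3O)c2n1` differs from compound 3 by amino in place of methoxy on an aromatic carbon. Among the compounds with values here, no measured step covers this exact swap, so a change beyond the scatter cannot be expected with confidence. The expected step is a step that the limit leaves unreadable from compound 3 to compound 4. Compound 4 is expected to give about 30000 nM, between 8000 nM and 100000 nM, with a further limit report quite likely.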

Compound 4, half-maximal inhibitory concentration: > 20000 nM
Compound 4: only a limit was reported; the forecaster's own chance of this, stated with the estimate: 75%; the middle value lies beyond the limit too.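

No new step can be read, because compound 1, compound 3 and compound 4 all stop at the same limit: the limit of > 20000 nM in this assay, at which 3 of the 4 values shown sit. Going by these compounds, how strongly these three compounds actually inhibit, and how far apart they lie, stays open.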